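Glucagon receptor antagonists: aryl variation on the spiro imidazolinone core

This account rests on a few compounds, and the source may have more. Where it says the series, first, only, none or still open, it means among the compounds named here.

Measured so far:
- compound 1, `C[C@H](c1ccc(C(=O)NCCC(=O)O)cc1)N1C(=O)C(c2cccc(C3CC3)c2)=N[C@]12CC[C@@H](C(C)(C)C)CC2`: 340 nM
- compound 2, `C[C@H](c1ccc(C(=O)NCCC(=O)O)cc1)N1C(=O)C(c2cccc(F)c2)=N[C@]12CC[C@@H](C(C)(C)C)CC2`: 560 nM
- compound 3, `CC(C)(C)[C@H]1CC[C@]2(CC1)N=C(c1cccc(C(F)(F)F)c1)C(=O)N2Cc1ccc(C(=O)NCCC(=O)O)cc1`: 510 nM

In a functional assay on CHO cells for antagonist activity at Glucagon receptor (Homo sapiens), read by cAMP accumulation, with stated times of 30 min and 45 min (a higher number here means a weaker inhibitor, a lower number a stronger inhibitor), compound 3 gives 510 nM, which stands second highest of the three numbers; its nearest neighbour is compound 2, and the gap to either compound 1 or compound 2 is within the scatter, so the three measured compounds cannot be ordered.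

Compound 4, `CC(C)(C)[C@H]1CC[C@]2(CC1)N=C(c1ccc(OC(F)(F)F)cc1)C(=O)N2Cc1ccc(C(=O)NCCC(=O)O)cc1`, is not yet measured. It differs from compound 3 in one place: 4-(trifluoromethoxy)phenyl in place of 3-(trifluoromethyl)phenyl on a carbon with a double bond to nitrogen.

For the measured compounds named here, only one measured step is available, a 1.6-fold higher number from compound 1 to compound 2 (0.22 log units; within the scatter), and it concerns the same aryl ring but a different pair of groups, on a core that also carries a different substituent on the ring nitrogen. Going by the values given here, compound 3 and compound 1 or compound 2 differ in two places, so no single step bears directly on the change to compound 4. The one aryl variation seen gave no step beyond the scatter, so for compound 4 the expected step of a 1.2-fold higher number from compound 3 to compound 4 (0.07 log units; within the scatter) in this assay is none beyond the scatter. Compound 4 is therefore estimated at 600 nM, with a range from 250 nM to 1500 nM.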

Compound 4, half-maximal inhibitory concentration: 1900 nM
Compound 4: the middle estimate sits 3.2-fold (0.50 log units) below what was measured; measured number outside the range, above it.
By their numbers in this assay, from the lowest: compounds 1, 3 and 2 (each within the scatter of the next); then compound 4.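

In this assay, 4-(trifluoromethoxy)phenyl in place of 3-(trifluoromethyl)phenyl gives a 3.7-fold higher number from compound 3 to compound 4 (0.57 log units; beyond the scatter). This is the only step in the shown compounds that lies beyond the scatter, so the aryl group on this carbon with a double bond to nitrogen does not tolerate every change equally. The change alters both where the phenyl ring is substituted and which group it carries, and the step cannot be divided between the two; no measurement shown here bears on what lies behind it.

Still open, from the compounds shown here alone, is whether the step follows the substitution site or the group, which 3-(trifluoromethoxy)phenyl and 4-(trifluoromethyl)phenyl on the core of compound 3 would separate. Also open, going by these compounds, is whether unsubstituted phenyl, or a phenyl bearing a nitrile, fits the same picture.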